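Replacing an amino alcohol with a cyclic amine on the core

The source may hold more compounds than are shown below. What is called first, only, known or untested is meant among the compounds shown, and "the series" means these compounds.

Measured compounds:
Compound 1, `CC(C)(C)OC(=O)N1CCC(CNc2ccc3nnnc(Nc4cccc(OC(F)(F)F)c4)c3n2)CC1`: > 100000 nM
Compound 2, `OCCNc1ccc2nnnc(Nc3cccc(OC(F)(F)F)c3)c2n1`: 42900 nM
Compound 3, `FC(F)(F)Oc1cccc(Nc2nnnc3ccc(N4CCC(N5CCCCC5)CC4)nc23)c1`: 4900 nM

Of the compounds shown here, three sharing one core have been measured in a functional assay on LNCaP cells (Homo sapiens) for antiproliferative activity, read by MTT assay, with a stated time of 96 h; on this read-out higher numbers stand for weaker inhibition and lower numbers for stronger inhibition. For compound 1 the result is a limit of the assay, > 100000 nM, and not a number, as stated in the limit of > 100000 nM in this assay, at which 1 of the 3 values shown sits. Of the two real numbers, compound 2 with 42900 nM stands highest; its nearest neighbour is compound 3, whose 4900 nM lies well beyond the scatter below it. Compound 3 carries a cyclic amine at the same place on the core where compound 2 carries the (2-hydroxyethyl)amino group.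

The next compound, compound 4 with `FC(F)(F)Oc1cccc(Nc2nnnc3ccc(N4CCNCC4)nc23)c1`, has not yet been measured in this assay. It differs from compound 2 in one place: piperazin-1-yl in place of (2-hydroxyethyl)amino on an aromatic carbon. Since compound 3, with 4900 nM, also bears a six-membered non-aromatic ring with basic nitrogen at this position, the step from compound 2 to compound 4 is expected to be a clear gain in potency, of a size around a 4.8-fold lower number from compound 2 to compound 4 (0.68 log units; beyond the scatter). Compound 4 is therefore estimated at 9000 nM, with a plausible range from 2500 nM to 30000 nM.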

Compound 4, half-maximal inhibitory concentration: 8510 nM
Beside the measured number, compound 4's estimate is 1.1-fold (0.02 log units) above it; measured number inside the range.
By their numbers in this assay, from the lowest: compounds 3 and 4 (each within the scatter of the next); then compound 2. At a limit, above all of these: compound 1.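

In this assay, the step at this position, on an aromatic carbon next to the ring nitrogen, can now be read as a single change: piperazin-1-yl in place of (2-hydroxyethyl)amino gives a 5.0-fold lower number from compound 2 to compound 4 (0.70 log units; beyond the scatter). The values of compound 3, 4900 nM, and compound 4, 8510 nM, lie within the scatter of each other, which shows that the piperazin-1-yl ring, with no second ring attached to it, already reaches the level of the larger cyclic amine on the shared core. Nothing measured here accounts for the size of this step.

On these data alone, it remains open whether the step follows from the ring as such or from its second nitrogen, a question that a morpholine or a plain piperidine at this place would address. Also open, as far as these compounds go, is how a methyl or an acetyl group on the free ring nitrogen of compound 4 would change the value, and whether a longer amino alcohol chain would behave like the (2-hydroxyethyl)amino group of compound 2.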